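Thiophen-2-yl to 5-methylfuran-2-yl: what to expect

The source may report more compounds than this note shows. Statements on the series, on what has been measured and on what is new or still open speak of the compounds shown alone.

Measured in a functional assay for agonist activity at growth hormone secretagogue receptor type 1 (Homo sapiens), read by FLIPR; on this read-out higher numbers stand for larger maximal responses and lower numbers for smaller maximal responses:
compound 1, `COc1ccc(N2C[C@@H](C)N[C@@H](C)C2)cc1NS(=O)(=O)c1ccc(-c2cc(Cl)ccc2F)cc1`, gives 1.
compound 2, `COc1ccc(N2C[C@@H](C)N[C@@H](C)C2)cc1NS(=O)(=O)c1ccc(-c2cncnc2)cc1`, gives 0.6.
compound 3, `COc1ccc(N2C[C@@H](C)N[C@@H](C)C2)cc1NS(=O)(=O)c1ccc(-c2cccs2)cc1`, gives 1.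

Compound 3 stands level with compound 1 at the digits shown, the two together the highest of the three, while compound 2 lies well apart: a number 0.40 higher from compound 2 to compound 3 (beyond the scatter). Compound 4, `COc1ccc(N2C[C@@H](C)N[C@@H](C)C2)cc1NS(=O)(=O)c1ccc(-c2ccc(C)o2)cc1`, differs from compound 3 in one place: 5-methylfuran-2-yl in place of thiophen-2-yl on an aromatic carbon. Among the compounds with values here, two steps bear on this. The swap of a six-membered carbocyclic ring for thiophen-2-yl gave no change at the digits printed from compound 1 to compound 3 (within the scatter), whereas the swap for pyrimidin-5-yl gave a number 0.40 lower from compound 1 to compound 2 (beyond the scatter). Since 5-methylfuran-2-yl, like thiophen-2-yl, is a five-membered aromatic ring with one hetero atom, compound 4 is expected to move little: a number 0.10 lower from compound 3 to compound 4 (within the scatter). The estimate for compound 4 is 0.9, between 0.7 and 1.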

Compound 4, intrinsic activity: the largest response reached, as a fraction of the reference agonist's: 1
Beside the measured number, compound 4's estimate is 0.10 below it, and the stated range covers the measured number.
By their numbers in this assay, from the lowest: compound 2; then compounds 1, 3 and 4 (each within the scatter of the next).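

In this assay, 5-methylfuran-2-yl in place of thiophen-2-yl gave no change at the digits printed from compound 3 to compound 4 (within the scatter), so this position accepts a furan bearing a methyl group as well as a thiophene. Against the other two rings, the same group gave no change at the digits printed from compound 1 to compound 4 (within the scatter) and a number 0.40 higher from compound 2 to compound 4 (beyond the scatter), which leaves pyrimidin-5-yl as the only one of the four groups set apart. Nothing available accounts for this difference.

The compounds shown leave open whether an aminomethyl or carboxylic acid group on the five-membered ring would keep this maximal response. They also leave open how a thiazole or an imidazole would behave here.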